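Ethyl to propyl on the imidazole of compound 2

The source may hold more compounds than are shown below. What is called first, only, known or untested is meant among the compounds shown, and "the series" means these compounds.

Compound 1 `CCc1nc(C)c(CN2CCN(c3cccc4[nH]c(-c5ccc(C(C)(C)C)cc5)nc34)CC2)o1` and compound 2 `CCn1cc(CN2CCN(c3cccc4[nH]c(-c5ccc(C(C)(C)C)cc5)nc34)CC2)nc1C` share one core and differ only in the group on the saturated chain carbon bound to the amine nitrogen in a ring. In an assay on isolated protein for displacement of a labelled ligand from Gonadotropin-releasing hormone receptor (Homo sapiens) (a higher number here means a weaker inhibitor, a lower number a stronger inhibitor), compound 1 gives 37 nM and compound 2 gives 10 nM; the step is a 3.7-fold lower number from compound 1 to compound 2 (0.57 log units; beyond the scatter). For the measured compounds named here, compound 2 thus stands at the lowest of the two numbers, with compound 1 as its only neighbour. Compound 3 `CCCn1cc(CN2CCN(c3cccc4[nH]c(-c5ccc(C(C)(C)C)cc5)nc34)CC2)nc1C` carries methyl in place of hydrogen on a saturated chain carbon, two bonds along the chain from an aromatic nitrogen; read one bond further out, this is ethyl to propyl. Going by the values given here, no measured step bears directly on this change: the single step from compound 1 to compound 2 swaps one heteroaryl group for another and says nothing about lengthening the chain on the aromatic nitrogen. For compound 3 in this assay the expected step is no change at the digits printed from compound 2 to compound 3 (within the scatter), none beyond the scatter. Compound 3 is therefore estimated at 10 nM, within 4 nM to 25 nM.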

Compound 3, half-maximal inhibitory concentration: 18 nM
For compound 3 the middle estimate is 1.8-fold (0.26 log units) below the measured one; the measured number falls inside the stated range.
By their numbers in this assay, from the lowest: compounds 2 and 3 (each within the scatter of the next); then compound 1.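

In this assay, the added methyl on the saturated chain carbon, two bonds along the chain from an aromatic nitrogen, gives a 1.8-fold higher number from compound 2 to compound 3 (0.26 log units; within the scatter), so ethyl and propyl cannot be told apart at this position. The imidazole also keeps its edge with propyl, at a 2.1-fold lower number from compound 1 to compound 3 (0.31 log units; beyond the scatter), so the lower number seen against the oxazole of compound 1 is not confined to the ethyl compound, although this step only just clears the scatter. No measurement at hand accounts for either step.

Two chain lengths do not define how far this position tolerates growth, and a butyl chain or a cyclopropylmethyl group would test that limit. A hydroxyethyl chain would show whether the position accepts a chain ending in a hydroxyl group.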